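A Smaller Amide at the Same Aromatic Carbon

This account rests on a few compounds, and the source may have more. Where it says the series, first, only, none or still open, it means among the compounds named here.

Measured so far in an assay on isolated protein (strain Sprague-Dawley) for inhibition of Amine oxidase [flavin-containing] B (Rattus norvegicus), read by spectrophotometry, with a stated time of 5 min; on this read-out higher numbers stand for weaker inhibition and lower numbers for stronger inhibition:
compound 1 `CCOC(=O)Nc1cc(=O)oc2cc(OCc3cccc(Cl)c3)ccc12` gives 589 nM
compound 2 `O=c1cc(CO)c2ccc(OCc3cccc(Br)c3)cc2o1` gives 14.1 nM

Compound 1 stands at the highest of the two numbers in this assay, and compound 2 sits far below it, a gap beyond the scatter of repeated measurements. The two compounds differ in more than one place, so no single step can be read between them; their two values simply show that compound 2 is the stronger inhibitor of the pair.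

Compound 3 `NC(=O)c1cc(=O)oc2cc(OCc3cccc(Cl)c3)ccc12` has not been measured. It differs from compound 1 in one place: carbamoyl in place of (ethoxycarbonyl)amino on an aromatic carbon. Both the leaving group and the entering group carry one hydrogen-bond donor, but the entering group is the smaller of the two and loses one acceptor.

Among the compounds with values here, with no measured step of this kind to lean on, the size of the change in this assay is uncertain. A modest move toward a lower number is expected, of about a 2.4-fold lower number from compound 1 to compound 3 (0.37 log units; beyond the scatter), and compound 3 is estimated at 250 nM, within a range from 50 nM to 1200 nM.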

Compound 3, half-maximal inhibitory concentration: 234 nM
Compound 3: the middle estimate sits 1.1-fold (0.03 log units) above what was measured, and the stated range covers the measured number.
By their numbers in this assay, from the lowest: compound 2; then compound 3; then compound 1.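

In this assay, within the data shown here, carbamoyl in place of (ethoxycarbonyl)amino on an aromatic carbon, opposite the ring oxygen, gives a 2.5-fold lower number from compound 1 to compound 3 (0.40 log units; beyond the scatter), the first change in this set that can be read at a single place. The step is modest but lies beyond the scatter, and it shows that the larger (ethoxycarbonyl)amino group is not needed at this position for inhibition to persist: the smaller carbamoyl, with fewer hydrogen-bond acceptors and the same count of donors, gives the lower number. No measurement at hand explains the step, so it cannot be assigned to the loss of size, the lost acceptor or anything else.

The compounds shown leave open how an amine, a carboxylic acid or a longer chain on the same aromatic carbon would compare with carbamoyl, and so whether the number keeps falling as the group shrinks. Compound 2 still differs from both compound 1 and compound 3 in more than one place, so the lower value of compound 2 at 14.1 nM cannot be assigned to any single one of its groups.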